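Acetamido replacing the aromatic ester: cytotoxicity notes

This account rests on a few compounds, and the source may have more. Where it says the series, first, only, none or still open, it means among the compounds named here.

In an ADME assay on Vero cells (Chlorocebus sabaeus) for cytotoxicity, read by MTT assay, with a stated time of 48 h (a lower number here means a stronger inhibitor, a higher number a weaker inhibitor), compound 1 (`O=C(OC1CCC(CN2CCN(c3cc(=O)c4cc(C(F)(F)F)cc([N+](=O)[O-])c4s3)CC2)CC1)c1ccccc1`) gives only a limit (> 64 ug/mL). Compound 2 (`Cc1ccc(C(=O)OC2CCC(CN3CCN(c4cc(=O)c5cc(C(F)(F)F)cc([N+](=O)[O-])c5s4)CC3)CC2)cc1`) also gives only a limit (> 64 ug/mL). Compound 3 (`COc1ccccc1C(=O)OC1CCC(CN2CCN(c3cc(=O)c4cc(C(F)(F)F)cc([N+](=O)[O-])c4s3)CC2)CC1`) likewise stands only at a limit (> 64 ug/mL). The change to compound 4 (`CC(=O)NC1CCC(CN2CCN(c3cc(=O)c4cc(C(F)(F)F)cc([N+](=O)[O-])c4s3)CC2)CC1`) is acetamido in place of ((2-methoxyphenyl)carbonyl)oxy on a saturated ring carbon. For the measured compounds named here, three measured steps bear on it, all inside the group that leaves: (a step that the two limits leave unreadable from compound 1 to compound 2), (a step that the two limits leave unreadable from compound 1 to compound 3) and (a step that the two limits leave unreadable from compound 2 to compound 3). None has a readable size, and what they share is a single ceiling (the limit of > 64 ug/mL in this assay, at which 3 of the 3 values shown sit). In this assay no step beyond the usual scatter is expected, in either direction (a step that the limit leaves unreadable from compound 3 to compound 4). Compound 4 is estimated at 90 ug/mL (expected range 40 ug/mL to 200 ug/mL).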

Compound 4, half-maximal inhibitory concentration: > 64 ug/mL
Compound 4: only a limit was reported; the forecaster's own chance of this, stated with the estimate: 85%; the middle value is on the limit's open side.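

In this assay compound 4 gives only a limit, > 64 ug/mL. For the compounds shown here, no step from compound 1, compound 2 or compound 3 to compound 4 can be read: the limit of > 64 ug/mL in this assay, at which 4 of the 4 values shown sit. The compounds shown leave open whether acetamido and the aromatic esters differ in cytotoxicity at all, since none of the four has a measured number.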